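Swapping dichlorophenyl for dimethoxyphenyl on the thiazole nitrogen

The source may report more compounds than this note shows. Statements on the series, on what has been measured and on what is new or still open speak of the compounds shown alone.

Two analogues of a shared core have been tested in a functional assay on HOP-92 cells (Homo sapiens) for cytotoxicity, read by sulforhodamine B assay, with a stated time of 48 h; on this read-out lower numbers stand for higher toxicity in this test and higher numbers for lower toxicity in this test. For the measured compounds named here, compound 2 `O=C(N/N=c1\scc(-c2ccc(Cl)cc2)n1-c1ccc(Cl)cc1Cl)c1ccc(O)cc1` gives 49000 nM, the only numerical value in the set. Compound 1 `COc1ccc(-c2cs/c(=N\NC(=O)c3ccc(O)cc3)n2-c2ccc(OC)cc2OC)cc1`, which also bears a 2,4-dimethoxyphenyl group, reaches only a limit of the assay, < 100000 nM, so the limit of < 100000 nM in this assay, at which 1 of the 2 values shown sits, is all that is known of it. Going by the values given here, no step between measured compounds is available.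

Compound 3 `COc1ccc(-n2c(-c3ccc(Cl)cc3)cs/c2=N\NC(=O)c2ccc(O)cc2)c(OC)c1` is not yet measured. It differs from compound 2 by 2,4-dimethoxyphenyl in place of 2,4-dichlorophenyl on an aromatic nitrogen. Among the compounds with values here, with no measured step to lean on, the expected change in this assay from compound 2 to compound 3 is small, at or near the scatter, with a slight lean toward lower toxicity, namely a 1.4-fold higher number from compound 2 to compound 3 (0.15 log units; within the scatter). Compound 3 is therefore expected to give about 70000 nM, most likely between 25000 nM and 160000 nM.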

Compound 3, concentration lethal to 50% of the cells: < 100000 nM
Compound 3 was reported as a limit; the forecaster's own chance of this, stated with the estimate: 35%; the middle value does not contradict the limit.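

Compound 3 is reported only as a limit, so neither its step from compound 2 nor its step from compound 1 can be read: the limit of < 100000 nM in this assay, at which 2 of the 3 values shown sit.

In this assay, the compounds shown leave open whether 2,4-dimethoxyphenyl in place of 2,4-dichlorophenyl on the aromatic nitrogen, or chloro in place of methoxy on an aromatic carbon, changes the value at all.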